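A few compounds are considered here, and "the series" means these few. Any claim that something is new, unique, unknown or untested is made for them only; others in the source may bear on it.

Compound 1 `CC(=O)OC[C@H]1C[C@]2(OC(=O)/C=C/c3ccccc3)C(=O)/C(C)=C/[C@@H]3[C@H](CC[C@@]4(C)O[C@@H]4[C@H]2[C@H]1O)C3(C)C`: 5.5
Compound 2 `CC(=O)OC[C@H]1C[C@]2(OC(=O)/C=C/c3ccccc3)C(=O)/C(C)=C/[C@@H]3[C@H](CC[C@@]4(C)O[C@@H]4[C@H]2[C@H]1OC(C)=O)C3(C)C`: 6.2

In a physicochemical assay for lipophilicity (a higher number here means a more lipophilic compound, a lower number a more polar compound), compound 1 is the lower of the two at 5.5. Compound 3 `C/C1=C\[C@@H]2[C@H](CC[C@@]3(C)O[C@@H]3[C@H]3[C@@H](O)[C@@H](COC(=O)c4ccccc4)C[C@]3(OC(=O)/C=C/c3ccccc3)C1=O)C2(C)C` alters it in one place, acetoxymethyl to (benzoyloxy)methyl: phenyl in place of methyl on a carbonyl carbon. Within the data shown here, the only measured step, a number 0.70 log units higher from compound 1 to compound 2 (beyond the scatter), is a different change, acetyl in place of hydrogen on an oxygen on a saturated carbon, so it offers only a rough guide. Among the measured compounds shown here, no measured pair shows phenyl in place of methyl. The expected change, an upward step somewhat larger than that guide, is a number 1.20 log units higher from compound 1 to compound 3 (beyond the scatter). Compound 3 is estimated at 6.7, within a range of 6.1 to 7.4.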

Compound 3, partition coefficient: 7.2
Beside the measured number, compound 3's estimate is 0.50 log units below it; the range from low to high includes it.
By their numbers in this assay, from the lowest: compound 1; then compound 2; then compound 3.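

In this assay, changing acetoxymethyl to (benzoyloxy)methyl, with phenyl in place of methyl on a carbonyl carbon, gives a number 1.70 log units higher from compound 1 to compound 3 (beyond the scatter) and this step is large. Among these compounds, the earlier compounds showed a change at another place only, so this is the first sign that the number responds to a change at this position. Nothing measured here explains the size of this step. Still open, from the compounds shown here alone, is how an ethyl group or a carboxylic acid in place of the methyl would read, and whether the phenyl step would hold in compound 2.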